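The source may report more compounds than this note shows. Statements on the series, on what has been measured and on what is new or still open speak of the compounds shown alone.

Working notes on the series

Compound 1 is `COc1cc(CC(O)c2ccc(-c3ccc(CO)cc3)cc2)c([N+](=O)[O-])cc1OC`. In an ADME assay on HeLa Rh cells (Homo sapiens) for cytotoxicity, read by microscopy (a lower number here means that less compound is tolerated, a higher number that more compound is tolerated), compound 1 gives only a limit, > 244000 nM. Compound 2 is `COc1cc(CC(O)c2ccc(-c3ccc(C)cc3)cc2)c([N+](=O)[O-])cc1OC`; in this assay compound 2 gives 4700 nM. Compound 3 is `COc1cc(CC(O)c2ccc(-c3ccc(Br)cc3)cc2)c([N+](=O)[O-])cc1OC`; in this assay compound 3 gives 4300 nM. Going by the values given here, of the two numbers so far, compound 3 and compound 2 are not separated, since a 1.1-fold lower number from compound 2 to compound 3 (0.04 log units; within the scatter); the third value is a limit, as noted for compound 1.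

The next compound, compound 4, is `COc1cc(CC(O)c2ccc(-c3cccc(CO)c3)cc2)c([N+](=O)[O-])cc1OC`, not yet measured in this assay. The change is 3-(hydroxymethyl)phenyl in place of 4-bromophenyl on an aromatic carbon. Among the compounds with values here, two measured steps bear on it. From compound 1 to compound 3 the change ran the other way, with the hydroxymethyl on a different position of the ring: an at least 56-fold lower number from compound 1 to compound 3 (1.75 log units; beyond the scatter). The step from compound 1 to compound 2 points the same way: an at least 51-fold lower number from compound 1 to compound 2 (1.71 log units; beyond the scatter). Both steps start from a limit, so their true size is only known as a minimum.

Reintroducing a hydroxymethyl is therefore expected to raise the number again, by a large step, a 28-fold higher number from compound 3 to compound 4 (1.45 log units; beyond the scatter), with a fair chance that compound 4 also returns only a limit. The estimate for compound 4 is 120000 nM, in a range from 20000 nM to 300000 nM.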

Compound 4, half-maximal cytotoxic concentration: 6000 nM
Estimate against measurement, compound 4: 20-fold (1.30 log units) above, outside the stated range (below it).
By their numbers in this assay, from the lowest: compounds 3, 2 and 4 (each within the scatter of the next). At a limit, above all of these: compound 1.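

The hydroxymethyl group by itself does not carry the high number in this assay: exchanging the 4-(hydroxymethyl)phenyl of compound 1 for the 3-(hydroxymethyl)phenyl gives an at least 40-fold lower number from compound 1 to compound 4 (1.60 log units; beyond the scatter). With the 3-(hydroxymethyl)phenyl in place, the number is not separated from those of the compounds lacking a hydroxymethyl on this ring, as shown by a 1.4-fold higher number from compound 3 to compound 4 (0.14 log units; within the scatter) and by a 1.3-fold higher number from compound 2 to compound 4 (0.11 log units; within the scatter). Among these four compounds, then, where the hydroxymethyl sits on the ring matters as much as whether it is present, and only compound 1 stands apart, with the size of its gap known only as a minimum since its value is a limit: the limit of > 244000 nM in this assay, at which 1 of the 4 values shown sits.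

The compounds shown hold a single pair that differs in where the hydroxymethyl sits, so it remains open whether the same gap would appear with other groups on this ring. Going by these compounds, it also remains open whether a carboxylic acid, an amine or a longer chain such as hydroxyethyl in place of the hydroxymethyl of compound 1 would keep the number at a limit or bring it back to the level of compound 2, compound 3 and compound 4.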